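Replacing the pyridyl of compound 3 with methylsulfanyl

This account rests on a few compounds, and the source may have more. Where it says the series, first, only, none or still open, it means among the compounds named here.

Compound 3 `COc1ccnc(-c2cnc(C(=O)CCCCCCc3ccccc3)o2)c1` gives 0.8 nM in an assay (Rattus norvegicus) for inhibition of Fatty-acid amide hydrolase 1 (Homo sapiens); on this read-out lower numbers stand for stronger inhibition and higher numbers for weaker inhibition. Among the three measured compounds it holds the second highest number: compound 2 `Cc1ccnc(-c2cnc(C(=O)CCCCCCc3ccccc3)o2)c1` with 0.6 nM lies nearest, the gap a 1.3-fold higher number from compound 2 to compound 3 (0.12 log units; within the scatter) being within the scatter, while compound 1 `Nc1ccccc1-c1cnc(C(=O)CCCCCCc2ccccc2)o1` with 750 nM lies furthest, a 940-fold lower number from compound 1 to compound 3 (2.97 log units; beyond the scatter).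

Compound 4 `CSc1cnc(C(=O)CCCCCCc2ccccc2)o1` differs from compound 3 by the change (methylsulfanyl in place of 4-methoxypyridin-2-yl on an aromatic carbon).

Within the data shown here, no measured step removes the aromatic ring from this position; the two large steps of a 1300-fold lower number from compound 1 to compound 2 (3.10 log units; beyond the scatter) and a 940-fold lower number from compound 1 to compound 3 (2.97 log units; beyond the scatter) only show that the identity of the group at this carbon governs the number strongly, and the step of a 1.3-fold higher number from compound 2 to compound 3 (0.12 log units; within the scatter) shows that exchanging methyl for methoxy on the pyridyl leaves it unchanged. Among the measured compounds shown here, with the whole ring gone, a large step toward higher numbers is expected for compound 4, on the order of a 630-fold higher number from compound 3 to compound 4 (2.80 log units; beyond the scatter), with wide uncertainty since no measured pair tests a group this small.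

Compound 4 is therefore estimated at 500 nM, with a range from 50 nM to 5000 nM.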

Compound 4, inhibition constant: 25 nM
Compound 4: middle estimate off by 20-fold (1.30 log units), on the high side; measured number outside the range, below it.
By their numbers in this assay, from the lowest: compounds 2 and 3 (each within the scatter of the next); then compound 4; then compound 1.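

In this assay, a ring at this carbon, next to the ring oxygen, is not needed for a low number: methylsulfanyl carries no ring, and the loss against the pyridyl groups is real but limited (a 31-fold higher number from compound 3 to compound 4 (1.49 log units; beyond the scatter); a 42-fold higher number from compound 2 to compound 4 (1.62 log units; beyond the scatter)). The same small group also gives a clear gain over 2-aminophenyl (a 30-fold lower number from compound 1 to compound 4 (1.48 log units; beyond the scatter)), so having an aromatic ring here does not by itself give the lower number, and compound 1 goes against any such reading. Nothing at hand accounts for this order.

Open, on these data alone, is whether sulfur matters or any small group would serve, which methoxy, dimethylamino or a longer chain such as butylsulfanyl at this carbon would test. Also open, as far as these compounds go, is how unsubstituted phenyl compares with 2-aminophenyl and the pyridyl groups.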